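The compounds below may be only part of what the source reports. "The series", "measured", "known", "first", "only" and "open" are said of these compounds alone.

Of the compounds shown here, three have been measured in an in vitro assay on HEK385-7 cells for displacement of a labelled ligand from prostaglandin D2 receptor 2 (Homo sapiens); a higher number here means a weaker inhibitor, a lower number a stronger inhibitor. Compound 1 `O=C(O)Cc1sc(NC(=O)c2ccccc2)nc1-c1ccc(Cl)cc1` gives 520 nM, and compound 2 `O=C(O)Cc1sc(C(c2ccccc2)c2ccccc2)nc1-c1ccccc1` gives 570 nM. Compound 3 `N#Cc1cc(-c2nc(C(c3ccc(F)cc3)c3ccc(F)cc3)sc2CC(=O)O)ccc1F` gives 57 nM, the lowest of the three numbers, and its gaps to compound 1 and to compound 2 are both beyond the scatter.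

Compound 4 `O=C(O)Cc1sc(C(c2ccc(F)cc2)c2ccc(F)cc2)nc1-c1ccoc1` differs from compound 3 in one place: furan-3-yl in place of 3-cyano-4-fluorophenyl on an aromatic carbon. The group that enters is smaller and carries neither the triple bond nor the fluorine. Among the compounds with values here, no measured pair shows this exact change, so the step is a guess; a rise in this assay beyond the scatter is expected, toward the numbers for compound 1 and compound 2. The expected step from compound 3 to compound 4 is a 5.3-fold higher number from compound 3 to compound 4 (0.72 log units; beyond the scatter), so compound 4 is estimated at 300 nM, between 80 nM and 1200 nM.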

Compound 4, half-maximal inhibitory concentration: 14 nM
Compound 4: middle estimate off by 21-fold (1.33 log units), on the high side; measured number outside the range, below it.
By their numbers in this assay, from the lowest: compound 4; then compound 3; then compounds 1 and 2 (each within the scatter of the next).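

In this assay, the swap to furan-3-yl gives a 4.1-fold lower number from compound 3 to compound 4 (0.61 log units; beyond the scatter) and so shows that this aromatic carbon, next to the ring nitrogen, does not need the 3-cyano-4-fluorophenyl group. A five-membered aromatic ring with fewer heavy atoms, and with no nitrile or fluorine, is tolerated and even preferred here. No measurement shown explains this gain. As far as these compounds go, whether the furan oxygen matters remains open, and thiophen-3-yl at this position would address that. A methyl group there would show whether any ring is needed at all.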